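A few compounds are considered here, and "the series" means these few. Any claim that something is new, unique, unknown or untested is made for them only; others in the source may bear on it.

Measured so far in a functional assay on MCF7 cells (Homo sapiens) for inhibition, read by MTT assay, with a stated time of 72 h; on this read-out lower numbers stand for stronger inhibition and higher numbers for weaker inhibition:
compound 1 `O=C(O)CCCCCCC(=O)Nc1ccc(C2=C(c3ccc(O)cc3)C3CC(S(=O)(=O)Oc4ccccc4C(F)(F)F)C2O3)cc1`: 26100 nM
compound 2 `Cc1ccc(OS(=O)(=O)C2CC3OC2C(c2ccc(NC(=O)CCCCCCC(=O)O)cc2)=C3c2ccc(O)cc2)cc1`: 60500 nM
compound 3 `O=C(CCCCCCC(=O)Nc1ccc(C2=C(c3ccc(O)cc3)C3CC(S(=O)(=O)Oc4cccc5ccccc45)C2O3)cc1)NO`: 13400 nM

Compound 2, at 60500 nM, has the highest number of the three. Compound 1 and compound 3 both lie lower.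

The next compound is compound 4 `O=C(O)CCCCCCC(=O)Nc1ccc(C2=C(c3ccc(O)cc3)C3CC(S(=O)(=O)Oc4ccc5ccccc5c4)C2O3)cc1`. It carries naphthalen-2-yl in place of 4-methylphenyl on an oxygen whose other neighbour is the sulfonyl sulfur: naphthalen-2-yl in place of 4-methylphenyl on an oxygen.

Among the measured compounds shown here, only one measured step bears on this place: a 2.3-fold higher number from compound 1 to compound 2 (0.37 log units; beyond the scatter), a modest step for 4-methylphenyl in place of 2-(trifluoromethyl)phenyl. For the measured compounds named here, compound 3 differs from compound 2 in more than one place, so it offers no single step. Going by the values given here, no naphthalen-2-yl compound has been measured, so the direction is an expectation resting on one step. Among the compounds with values here, the only other group measured at this place, in compound 1, gives a lower number, 26100 nM. In this assay, a step of similar modest size toward a lower number is therefore expected: a 2.2-fold lower number from compound 2 to compound 4 (0.33 log units; beyond the scatter). The estimate for compound 4 is 28000 nM, with an expected range of 12000 nM to 65000 nM.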

Compound 4, half-maximal inhibitory concentration: 18900 nM
For compound 4 the middle estimate is 1.5-fold (0.17 log units) above the measured one, and the stated range covers the measured number.
By their numbers in this assay, from the lowest: compounds 3, 4 and 1 (each within the scatter of the next); then compound 2.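

Replacing 4-methylphenyl with naphthalen-2-yl on the oxygen whose other neighbour is the sulfonyl sulfur gives, in this assay, a 3.2-fold lower number from compound 2 to compound 4 (0.51 log units; beyond the scatter), so 4-methylphenyl now stands against two other groups at this place rather than one. Replacing 2-(trifluoromethyl)phenyl with naphthalen-2-yl gives a 1.4-fold lower number from compound 1 to compound 4 (0.14 log units; within the scatter), so these two groups cannot be told apart here, although naphthalen-2-yl has two six-membered aromatic rings. Nothing at hand explains why compound 2 differs from compound 1 and compound 4.

Open, from the compounds shown here alone, is whether an aryl group carrying an amine or a methoxy group on this oxygen would fall with 4-methylphenyl or with the other two groups. Also open, going by these compounds, is how naphthalen-2-yl behaves when the chain ends in a hydroxamic acid, since compound 3 differs from compound 4 in more than one place.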